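The source may hold more compounds than are shown below. What is called first, only, known or untested is meant among the compounds shown, and "the series" means these compounds.

Measured compounds:
- compound 1, `Nc1cc(N)c2nc(-c3ccccc3)c(Oc3ccc(Cl)c(Cl)c3)nc2c1`: in a functional assay on RPMI8266 cells (Homo sapiens) for inhibition, read by sulforhodamine B assay, with a stated time of 48 h (on this read-out lower numbers stand for stronger inhibition of growth and higher numbers for weaker inhibition of growth), compound 1 gives < 100000 nM
- compound 2, `COc1ccc(CNc2nc3cc(N)cc(N)c3nc2-c2ccccc2)cc1OC`: compound 2 gives 7240 nM
- compound 3, `COc1cc(CNc2nc3cc(N)cc(N)c3nc2-c2ccccc2)cc(OC)c1OC`: compound 3 gives 3020 nM.

For compound 1 the value is a limit of the assay and not a number, which is recorded as the limit of < 100000 nM in this assay, at which 1 of the 3 values shown sits. Going by the values given here, compound 2 and compound 3 carry a benzylamino group on the shared core, and the one measured step between them, a 2.4-fold lower number from compound 2 to compound 3 (0.38 log units; beyond the scatter), concerns a methoxy on that benzyl ring.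

Compound 4, `Nc1cc(N)c2nc(-c3ccccc3)c(Sc3ccc(F)cc3)nc2c1`, differs from compound 1 in a different place: (4-fluorophenyl)sulfanyl in place of 3,4-dichlorophenoxy on an aromatic carbon. Among the compounds with values here, no measured step touches an aryl group bound through oxygen or sulfur at this position, so the step from compound 1 to compound 4 cannot be read from the benzylamine pair, and compound 1 itself offers only a limit to start from. Compound 4 is therefore expected at 30000 nM, within a wide range from 5000 nM to 100000 nM. This estimate would mean a step that the limit leaves unreadable from compound 1 to compound 4, with a real chance that only a limit is reported.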

Compound 4, concentration for total growth inhibition: 81300 nM
Estimate against measurement, compound 4: 2.7-fold (0.43 log units) below; the measured number falls inside the stated range.
By their numbers in this assay, from the lowest: compound 3; then compound 2; then compound 4.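

No new step can be read from compound 1 to compound 4, since the value of compound 1 is a limit of the assay and not a number: the limit of < 100000 nM in this assay, at which 1 of the 4 values shown sits.

The compounds shown leave open how far (4-fluorophenyl)sulfanyl in place of 3,4-dichlorophenoxy changes growth inhibition on the shared core.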